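This account rests on a few compounds, and the source may have more. Where it says the series, first, only, none or still open, it means among the compounds named here.

In a functional assay on MCF7 cells (Homo sapiens) for cytotoxicity, read by MTT assay, with a stated time of 48 h (a lower number here means a stronger inhibitor, a higher number a weaker inhibitor), compound 1 (`Cc1cc(C(=O)c2ccccc2Br)ccc1OCC(=O)NNC(=O)c1cc2ccccc2oc1=O`) gives 7600 nM and compound 2 (`Cc1ccc(C(=O)c2cc(F)c(OCC(=O)NNC(=O)c3cc4ccccc4oc3=O)c(Cl)c2)cc1`) gives 9300 nM. Going by the values given here, these two values lie within the usual scatter of each other, so compound 1 stands level with the only other measured compound. Compound 3 (`Cc1cc(C(=O)c2ccc(Cl)cc2Cl)ccc1OCC(=O)NNC(=O)c1cc2ccccc2oc1=O`) keeps the core of compound 1 but carries 2,4-dichlorophenyl in place of 2-bromophenyl on a carbonyl carbon. Among the compounds with values here, no measured pair of compounds differs in one place only, so the data offer no direct guide to this change. The expectation in this assay is therefore no shift beyond the scatter, in either direction. Compound 1 and compound 2 differ in more than one place, yet their values sit together, and this supports that expectation. The estimated step is a 1.1-fold lower number from compound 1 to compound 3 (0.04 log units; within the scatter). For compound 3 the expected value is 7000 nM, with an estimated range of 3000 nM to 16000 nM.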

Compound 3, half-maximal inhibitory concentration: 10200 nM
The estimate for compound 3 lay 1.5-fold (0.16 log units) below the measured number; the range from low to high includes it.
By their numbers in this assay, from the lowest: compounds 1, 2 and 3 (each within the scatter of the next).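

In this assay, 2,4-dichlorophenyl in place of 2-bromophenyl on a carbonyl carbon gives a 1.3-fold higher number from compound 1 to compound 3 (0.13 log units; within the scatter). Going by these compounds alone, this is the first pair that differs in one place only, so the position now has a direct reading: exchanging one of these halogen-bearing phenyl groups for the other leaves the number within the scatter. No measured property of either group is at hand to account for this result.

As far as these compounds go, both groups compared at this position are halogen-bearing phenyl groups, so it remains open whether an unsubstituted phenyl, a methoxyphenyl or an aminophenyl would read the same. Also open, from the compounds shown here alone, is whether a change elsewhere on the shared core, such as a carboxylic acid in place of the methyl group, would move the number beyond the scatter.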